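The source may report more compounds than this note shows. Statements on the series, on what has been measured and on what is new or still open speak of the compounds shown alone.

Compound 2 `O=C(NCCO)c1cccc(Nc2ncc(F)c(Nc3ccc(F)cc3)n2)c1` gives 21400 nM in a functional assay on KBVIN cells (Homo sapiens) for antiproliferative activity, read by sulforhodamine B assay, with a stated time of 3 days (on this read-out lower numbers stand for stronger inhibition of growth and higher numbers for weaker inhibition of growth), the higher of the two numbers shown, though within the scatter of compound 1 `O=C(c1cccc(Nc2ncc(F)c(Nc3ccc(F)cc3)n2)c1)N1CCCCC1`, which gives 13800 nM. Compound 3 `Cn1ccnc1NC(=O)c1cccc(Nc2ncc(F)c(Nc3ccc(F)cc3)n2)c1` differs from compound 2 by 1-methyl-1H-imidazol-2-yl in place of 2-hydroxyethyl on an amide-type nitrogen. Within the data shown here, the one step that bears on this position, a 1.6-fold higher number from compound 1 to compound 2 (0.19 log units; within the scatter), stayed within the scatter, so the amide substituent has so far moved the number little. A further exchange on the same amide-type nitrogen is therefore expected to give a step of a 1.4-fold lower number from compound 2 to compound 3 (0.15 log units; within the scatter), within the scatter. Compound 3 is estimated at 15000 nM, with a range from 5000 nM to 45000 nM.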

Compound 3, concentration for 50% growth inhibition: 13100 nM
Compound 3: the middle estimate sits 1.1-fold (0.06 log units) above what was measured; low and high end bracket the measured number.
By their numbers in this assay, from the lowest: compounds 3, 1 and 2 (each within the scatter of the next).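

Putting a five-membered aromatic ring on the amide-type nitrogen, as 1-methyl-1H-imidazol-2-yl in place of 2-hydroxyethyl, leaves the number in this assay within the scatter (a 1.6-fold lower number from compound 2 to compound 3 (0.21 log units; within the scatter)). The same holds against the piperidin-1-yl amide (a 1.1-fold lower number from compound 1 to compound 3 (0.02 log units; within the scatter)), so an open chain, a saturated ring and an aromatic ring at this position all give numbers within the scatter of one another. Nothing measured here explains this closeness. On these data alone, whether a carboxylic acid or a primary amine on a longer chain at this nitrogen would move the number beyond the scatter remains open.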